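Replacing one group on the chain of compound 3

The source may report more compounds than this note shows. Statements on the series, on what has been measured and on what is new or still open speak of the compounds shown alone.

In a physicochemical assay for solubility, in phosphate buffer, with a stated time of 18 h, at pH 7.4 (a higher number here means a more soluble compound, a lower number a less soluble compound), compound 1 (`COc1cc2ncnc(-n3nc(N)nc3N)c2cc1OC`) gives 83000 nM, compound 2 (`COc1cc2ncnc(-n3nc(-c4ccccn4)nc3N)c2cc1OCCCNC(=O)CN1C[C@@H](C)O[C@@H](C)C1`) gives 34000 nM, and compound 3 (`COc1cc2ncnc(-n3nc(-c4ccccn4)nc3N)c2cc1OCCCCNC(=O)OC(C)(C)C`) gives 500 nM, the lowest of the three numbers. Compound 4 (`COc1cc2ncnc(-n3nc(-c4ccccn4)nc3N)c2cc1OCCCNC(=O)C(F)(F)F`) has not been measured yet. It carries ((trifluoromethyl)carbonyl)amino in place of ((tert-butoxycarbonyl)amino)methyl on a saturated chain carbon, three bonds along the chain from an oxygen on an aromatic ring.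

Going by the values given here, only one measured step changes the same place: a 68-fold lower number from compound 2 to compound 3 (1.83 log units; beyond the scatter), a large drop beyond the scatter. That drop came with the arrival of the ((tert-butoxycarbonyl)amino)methyl group, the very group that compound 4 gives up. Among the compounds with values here, the group entering in compound 4 has no measured example here, so this single step sets the direction better than the size. A moderate rise is therefore expected, much smaller than that drop, and the estimated step is a 4.0-fold higher number from compound 3 to compound 4 (0.60 log units; beyond the scatter). For compound 4 the estimate is 2000 nM, with an expected range from 400 nM to 10000 nM.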

Compound 4, solubility: 1000 nM
Compound 4: middle estimate off by 2.0-fold (0.30 log units), on the high side; the measured number falls inside the stated range.
By their numbers in this assay, from the lowest: compounds 3 and 4 (each within the scatter of the next); then compound 2; then compound 1.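

In this assay the exchange of the 4-((tert-butoxycarbonyl)amino)butyl group for 3-(((trifluoromethyl)carbonyl)amino)propyl gives a 2.0-fold higher number from compound 3 to compound 4 (0.30 log units; within the scatter) and so leaves no real difference between these two end groups. With the propyl chain kept, trifluoromethyl in place of (2,6-dimethylmorpholin-4-yl)methyl on a carbonyl carbon gives a 34-fold lower number from compound 2 to compound 4 (1.53 log units; beyond the scatter) and shows that the large gap seen earlier does not need the butyl chain or the tert-butoxycarbonyl group. Nothing available here explains these numbers.

Still open, on these data alone, is whether the high number of compound 2 needs the 2,6-dimethylmorpholine ring itself, or whether a simple dimethylamine or a carboxylic acid on the same chain would behave alike. The trifluoromethyl amide on the longer butyl chain also remains an open comparison.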